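The compounds below may be only part of what the source reports. "The series", "measured", "known", "first", "only" and "open" are said of these compounds alone.

Compound 1 `O=C1N(CCCCCCOc2ccc(Br)cc2)CCN1c1ccnc(Cl)c1` is one of three compounds examined in a functional assay on cells (Homo sapiens) for cytotoxicity; a higher number here means that more compound is tolerated, a lower number that less compound is tolerated. In this assay compound 1 gives > 25000 nM, which is a limit of the assay rather than a number. Compound 2 `O=C1N(CCCCCOc2ccc(Br)cc2)CCN1c1ccnc(Cl)c1` likewise gives > 25000 nM, again a limit. Compound 3 `CSc1ccc(OCCCCCCN2CCN(c3ccnc(Cl)c3)C2=O)cc1` also reaches only a limit at > 25000 nM. The two measured steps, a step that the two limits leave unreadable from compound 1 to compound 2 and a step that the two limits leave unreadable from compound 1 to compound 3, therefore cannot be read, since (the limit of > 25000 nM in this assay, at which 3 of the 3 values shown sit). Compound 4 `O=C1N(CCCCCCOc2ccc(Br)cc2)CCN1c1ccccc1` differs from compound 1 by phenyl in place of 2-chloropyridin-4-yl on an amide-type nitrogen in a ring. Neither measured step touches the amide-type nitrogen in a ring, so no readable guide exists for this change. The step that the limit leaves unreadable from compound 1 to compound 4 is expected to be none beyond the scatter. Compound 4 is accordingly expected to give 30000 nM, with a range from 15000 nM to 60000 nM.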

Compound 4, half-maximal cytotoxic concentration: > 25000 nM
Compound 4 ended at the assay's limit; the forecaster's own chance of this, stated with the estimate: 85%; the middle value lies beyond the limit too.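

For the compounds shown here, compound 1 and compound 4 both sit at a limit, so no step between them can be read: the limit of > 25000 nM in this assay, at which 4 of the 4 values shown sit. The compounds shown leave open whether any of these changes shifts the read-out in this assay, as none gives an actual number.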